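The source may report more compounds than this note shows. Statements on the series, on what has been measured and on what is new or still open speak of the compounds shown alone.

Measured in a functional assay on Fem-X cells (Homo sapiens) for cytotoxicity, read by MTT assay, with a stated time of 72 h; on this read-out higher numbers stand for weaker inhibition and lower numbers for stronger inhibition:
- compound 1 `CSCC[C@H](NC1=CC(=O)C=C(C[C@]2(C)[C@@H](C)CC[C@]3(C)C(C)=CCC[C@@H]23)C1=O)C(=O)O`: 19400 nM
- compound 2 `CC1=CCC[C@H]2[C@](C)(CC3=CC(=O)C=C(NCC(=O)O)C3=O)[C@@H](C)CC[C@]12C`: 17800 nM
- compound 3 `CC1=CCC[C@H]2[C@](C)(CC3=CC(=O)C=C(N[C@@H](C)C(=O)O)C3=O)[C@@H](C)CC[C@]12C`: not yet measured

Among the compounds with values here, only two numbers exist so far, and compound 2, at 17800 nM, lies within the scatter of compound 1. Compound 3 carries methyl in place of hydrogen on a saturated chain carbon bound to an amine nitrogen and a carbonyl carbon. One measured step changes this same place, a 1.1-fold lower number from compound 1 to compound 2 (0.04 log units; within the scatter), and it stayed within the scatter. No change beyond the scatter is therefore expected in this assay, and the expected result is a 1.0-fold higher number from compound 2 to compound 3 (0.00 log units; within the scatter). The estimated value for compound 3 is 18000 nM, with an expected range of 10000 nM to 32000 nM.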

Compound 3, half-maximal inhibitory concentration: 10300 nM
For compound 3 the middle estimate is 1.7-fold (0.24 log units) above the measured one; low and high end bracket the measured number.
By their numbers in this assay, from the lowest: compounds 3, 2 and 1 (each within the scatter of the next).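

In this assay methyl in place of hydrogen on the saturated chain carbon bound to an amine nitrogen and a carbonyl carbon gives a 1.7-fold lower number from compound 2 to compound 3 (0.24 log units; within the scatter) and the pair with the larger side chain gives a 1.9-fold lower number from compound 1 to compound 3 (0.27 log units; within the scatter) as its step. Hydrogen, methyl and 2-(methylsulfanyl)ethyl at this carbon thus all lie within the scatter of one another, so the methyl adds a small side chain to the one larger example. Nothing shown explains this result.

Open, as far as these compounds go, is whether a phenyl ring, an amine on a longer chain or a second carboxylic acid at this carbon would move the number beyond the scatter.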